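The source may hold more compounds than are shown below. What is called first, only, known or untested is meant among the compounds shown, and "the series" means these compounds.

The three measured compounds, all tested in a functional assay on cells (T-cell, Mus musculus, strain BALB/c) for inhibition, read by MTT assay, with stated times of 24 h and 72 h (on this read-out lower numbers stand for stronger inhibition and higher numbers for weaker inhibition), are:

compound 1, `COc1cc(-c2nnc(SCc3ccccc3F)o2)ccc1O`, which gives 5790 nM;
compound 2, `COc1cc(-c2nnc(SCc3ccc(F)cc3F)o2)ccc1O`, which gives 9690 nM;
compound 3, `COc1cccc(CSc2nnc(-c3ccc(O)c(OC)c3)o2)c1`, which gives 7410 nM.

Compound 1 holds the smallest of the three numbers, but nothing sets it apart: the step of a 1.3-fold higher number from compound 1 to compound 3 (0.11 log units; within the scatter) and the step of a 1.7-fold higher number from compound 1 to compound 2 (0.22 log units; within the scatter) both lie within the scatter, as does the step of a 1.3-fold lower number from compound 2 to compound 3 (0.12 log units; within the scatter). The three compounds share one core and differ only in the group on the saturated chain carbon bound to a sulfur, and none of those changes moved the number beyond what repeated measurement would give.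

Compound 4, `COc1cc(-c2nnc(SCc3ccccc3F)o2)ccc1OCc1ccccc1F`, differs from compound 1 in another place: 2-fluorobenzyl in place of hydrogen on an oxygen on an aromatic ring. Among the compounds with values here, no measured step touches that oxygen, so none bears directly on this change. Within the data shown here, the only guidance is that three changes elsewhere on the shared core left the number within the scatter. On that basis compound 4 is expected to show a step of a 1.1-fold higher number from compound 1 to compound 4 (0.05 log units; within the scatter), that is, no change beyond the scatter in this assay. The estimate for compound 4 is 6500 nM, with a range from 2500 nM to 17000 nM.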

Compound 4, half-maximal inhibitory concentration: 4760 nM
Compound 4: middle estimate off by 1.4-fold (0.14 log units), on the high side; measured number inside the range.
By their numbers in this assay, from the lowest: compounds 4, 1, 3 and 2 (each within the scatter of the next, the first and the last beyond it).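

In this assay, within the data shown here, the step of a 1.2-fold lower number from compound 1 to compound 4 (0.09 log units; within the scatter) is the first reading at the oxygen on an aromatic ring, a position that the earlier compounds left untouched. It shows that, in this one pair, the hydrogen on that oxygen can give way to 2-fluorobenzyl, a group of 8 heavy atoms with its own six-membered aromatic ring, without the number moving beyond the scatter, so the hydroxy group is not required to keep the number in this range. No measurement offered here explains why so large an addition left the number where it was.

With only one group shown on this oxygen, it remains open whether a small group such as methyl, a longer chain ending in an amine or a carboxylic acid would also leave the number within the scatter. On these data alone, it is also open whether (2-fluorobenzyl)oxy would behave the same way on the cores of compound 2 and compound 3, which carry 2,4-difluorophenyl and 3-methoxyphenyl on the saturated chain carbon bound to a sulfur.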